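Swapping a six-ring for a five-ring on a purine nitrogen

This account rests on a few compounds, and the source may have more. Where it says the series, first, only, none or still open, it means among the compounds named here.

Measured so far:
- compound 1, `CCCCCCCCCCSc1ncnc2c1ncn2C1CCCCC1`: "not determined" (no result reported)
- compound 2, `Nc1nc(Oc2ccc(Cl)cc2)c2nc[nH]c2n1`: "not determined" (no result reported)
- compound 3, `CCCCCCCCCCSc1nc(N)nc2c1ncn2CC`: 12.3 ug/mL

Three compounds of this series have been run in an ADME assay on Vero cells (Chlorocebus sabaeus) for cytotoxicity (on this read-out lower numbers stand for higher toxicity in this test and higher numbers for lower toxicity in this test), but only one of them has come back with a number. Compound 1 carries a cyclohexyl on a ring nitrogen of its core and has no result; compound 2 likewise has none. Compound 3 shares the long decylthio chain of compound 1 but carries an ethyl on the ring nitrogen. In this assay compound 3 gives 12.3 ug/mL. So compound 1 stands nowhere yet: there is no figure for it, and no figure for the compound closest to it in shape either.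

The next compound, compound 4, `CCCCCCCCCCSc1ncnc2c1ncn2C1CCCC1`, differs from compound 1 in one place: cyclopentyl in place of cyclohexyl on an aromatic nitrogen. Among the compounds with values here, with no measured pair showing what this kind of change does, and no number for compound 1 itself, the expectation in this assay is that compound 4 lands close to the one value that exists, with no step beyond the scatter foreseen in either direction. The decylthio chain is shared with compound 3, whose 12.3 ug/mL is the only anchor. Compound 4 is therefore expected to give about 10 ug/mL, within a range of 3 ug/mL to 35 ug/mL.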

Compound 4, half-maximal cytotoxic concentration: 8.04 ug/mL
For compound 4 the middle estimate is 1.2-fold (0.09 log units) above the measured one; measured number inside the range.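

In this assay, within the data shown here, compound 1 stands at "not determined" (no result reported), and no step from cyclohexyl to cyclopentyl can be read between compound 1 and compound 4. Nothing shown offers an explanation for the result of compound 4. The compounds shown leave open what this change of ring does to the read-out of this assay.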